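A few compounds are considered here, and "the series" means these few. Any claim that something is new, unique, unknown or untested is made for them only; others in the source may bear on it.

Series notes: in a functional assay on GOTO cells (Homo sapiens) for cytotoxicity, read by MTT assay, with a stated time of 3 days (a lower number here means a stronger inhibitor, a higher number a weaker inhibitor), compound 1 `N#Cc1c(Cl)nc(SCc2nc3ccccc3[nH]2)nc1-c1ccccc1` gives 8.62 nM, while compound 2 `N#Cc1c(NN)nc(SCc2nc3ccccc3[nH]2)nc1-c1ccccc1` gives 2.68 nM. Among the compounds with values here, compound 2 therefore holds the lower of the two numbers so far. Compound 3 `N#Cc1c(Nc2ccccn2)nc(SCc2nc3ccccc3[nH]2)nc1-c1ccccc1` is reached from compound 2 by pyridin-2-yl in place of amino on a nitrogen on an aromatic ring, which places pyridin-2-yl in place of amino on a nitrogen on an aromatic ring. Within the data shown here, only one measured step bears on this change: a 3.2-fold lower number from compound 1 to compound 2 (0.51 log units; beyond the scatter), a modest move beyond the scatter, made at the same place on the shared core. That single step gives a rough size but says little about direction, so a modest change in this assay is the working expectation, leaning towards a higher number. The expected step is a 1.9-fold higher number from compound 2 to compound 3 (0.27 log units; within the scatter). For compound 3 the estimated value is 5 nM, with an expected range of 1.5 nM to 18 nM.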

Compound 3, half-maximal inhibitory concentration: 2.5 nM
Estimate against measurement, compound 3: 2.0-fold (0.30 log units) above; the range from low to high includes it.
By their numbers in this assay, from the lowest: compounds 3 and 2 (each within the scatter of the next); then compound 1.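

In this assay, the nitrogen on the aromatic ring takes a much larger group without a step beyond the scatter: a 1.1-fold lower number from compound 2 to compound 3 (0.03 log units; within the scatter), with pyridin-2-yl, a six-membered aromatic ring, in place of amino. Set against the chloro compound, a 3.4-fold lower number from compound 1 to compound 3 (0.54 log units; beyond the scatter), so a second nitrogen-linked group, this one carrying a ring, also stands beyond the scatter from compound 1. Nothing measured alongside these numbers bears on the result.

Still open, from the compounds shown here alone, is whether the difference from chloro follows the linking nitrogen itself or the group it carries, which a simple amine or a phenyl on the same nitrogen could help separate. Going by these compounds, it is also open whether a carboxylic acid or a longer alkyl chain at this nitrogen would stay within the scatter of compound 3.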